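This account rests on a few compounds, and the source may have more. Where it says the series, first, only, none or still open, it means among the compounds named here.

For compound 1 `COc1cc(-c2cc(C(=O)O)c3ccccc3n2)ccc1OCC(=O)Nc1ccccc1`, an ADME assay on HaCaT cells (Homo sapiens) for inhibition (a higher number here means a weaker inhibitor, a lower number a stronger inhibitor), returns a limit, > 300000 nM, and not a number. Among the compounds with values here, compound 2 `COc1cc(-c2cc(C(=O)O)c3ccccc3n2)ccc1OCC(=O)Nc1ccccc1Cl` gives 210000 nM, the only number so far in this assay. Compound 3 `COc1cc(-c2cc(C(=O)O)c3ccccc3n2)ccc1OCC(=O)Nc1cccc(C(F)(F)F)c1` differs from compound 2 by 3-(trifluoromethyl)phenyl in place of 2-chlorophenyl on an amide-type nitrogen, with 3-(trifluoromethyl)phenyl in place of 2-chlorophenyl on an amide-type nitrogen. Within the data shown here, the one measured step that bears on this site is an at least 1.4-fold lower number from compound 1 to compound 2 (0.15 log units; that floor lies within the scatter), chloro in place of hydrogen on an aromatic carbon. That step gives no direction beyond the scatter, so the expected change in this assay is a 1.1-fold lower number from compound 2 to compound 3 (0.02 log units; within the scatter), which is no real shift. Compound 3 is estimated at 200000 nM, within a range of 80000 nM to 400000 nM.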

Compound 3, half-maximal inhibitory concentration: 160000 nM
Estimate against measurement, compound 3: 1.3-fold (0.10 log units) above; measured number inside the range.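

In this assay, 3-(trifluoromethyl)phenyl in place of 2-chlorophenyl on the amide-type nitrogen gives a 1.3-fold lower number from compound 2 to compound 3 (0.12 log units; within the scatter), so exchanging one substituted phenyl for another at this position shows no real shift. The trifluoromethyl step gives an at least 1.8-fold lower number from compound 1 to compound 3 (0.27 log units; that floor lies within the scatter), which, like the chloro step, reads only as a floor. Compound 1 remains a limit and not a number: the limit of > 300000 nM in this assay, at which 1 of the 3 values shown sits.

Still open, as far as these compounds go, is whether an amine or a carboxylic acid on this phenyl ring would move the number beyond the scatter. From the compounds shown here alone, a longer chain between the amide-type nitrogen and the ring is equally open.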